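Aniline variation on a shared core: outlook for compound 4

The source may hold more compounds than are shown below. What is called first, only, known or untested is meant among the compounds shown, and "the series" means these compounds.

Compound 1 `Fc1cccc(-c2nc(Nc3ccccc3F)c3cc(F)ccc3n2)c1` — in a functional assay on HL-60 cells (Homo sapiens) for cytotoxicity, read by MTT assay, with a stated time of 48 h (on this read-out lower numbers stand for stronger inhibition and higher numbers for weaker inhibition), compound 1 returns only a limit, > 50000 nM.
Compound 2 `Fc1cccc(-c2nc(Nc3ccccc3Br)c3cc(F)ccc3n2)c1` — in this assay compound 2 likewise returns only a limit, > 50000 nM.
Compound 3 `Oc1ccc(Nc2nc(-c3cccc(F)c3)nc3ccc(F)cc23)cc1` — in this assay compound 3 also returns only a limit, > 50000 nM.

Compound 3 thus stands at a limit, not at a number, and the same holds for the two companions: the limit of > 50000 nM in this assay, at which 3 of the 3 values shown sit. The step from compound 1 to compound 2 is a step that the two limits leave unreadable from compound 1 to compound 2, the step from compound 1 to compound 3 is a step that the two limits leave unreadable from compound 1 to compound 3, and the step from compound 2 to compound 3 is a step that the two limits leave unreadable from compound 2 to compound 3. None of them yields a readable size.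

Compound 4 `Nc1ccccc1Nc1nc(-c2cccc(F)c2)nc2ccc(F)cc12` differs from compound 3 by 2-aminophenyl in place of 4-hydroxyphenyl on a nitrogen on an aromatic ring. Among the compounds with values here, no measured step bears on this change in a readable way, so the only guide is that every measured compound sits at the limit. On that basis compound 4 is expected to give 60000 nM, with a range of 10000 nM to 200000 nM. The expected step is accordingly a step that the limit leaves unreadable from compound 3 to compound 4, none beyond the scatter, with a further limit being the most probable outcome.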

Compound 4, half-maximal inhibitory concentration: 41300 nM
Beside the measured number, compound 4's estimate is 1.5-fold (0.16 log units) above it; low and high end bracket the measured number.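

In this assay compound 4 gives 41300 nM, a number rather than a limit, which makes the (2-aminophenyl)amino group the first on the shared core to return a measurable value. As far as these compounds go, the change reads as an at least 1.2-fold lower number from compound 3 to compound 4 (0.08 log units; that floor lies within the scatter), as an at least 1.2-fold lower number from compound 2 to compound 4 (0.08 log units; that floor lies within the scatter) and as an at least 1.2-fold lower number from compound 1 to compound 4 (0.08 log units; that floor lies within the scatter); each of these is only a floor, so the true size of the steps stays unknown and none is established as a real separation. The steps among the other three compounds cannot be read, and those compounds stay at a limit: the limit of > 50000 nM in this assay, at which 3 of the 4 values shown sit.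

From the compounds shown here alone, whether a 4-aminophenyl, a 2-hydroxyphenyl or a 2-(dimethylamino)phenyl on the same nitrogen would also give a number remains open, and so does whether the amino group itself or its place on the ring matters. Also open, going by these compounds, is whether any group at this position can reach a value well clear of the limit.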